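The compounds below may be only part of what the source reports. "The series", "measured", "known", "first", "only" and "open" are said of these compounds alone.

Measured so far: compound 1 `CCCc1nc(-c2ccccc2)c(CNCCN2CCN(c3cccc(C)c3C)CC2)o1` gives 66.7% in an assay on HEK293 cells for inhibition of Voltage-dependent T-type calcium channel subunit alpha-1G (Homo sapiens), read by fluorescence, tested at 10 uM; a lower number here means less inhibition, a higher number more inhibition at the concentration tested (going by the name of the read-out); compound 2 `CCCc1nc(-c2ccccc2)c(CNCCN2CCN(c3ccccc3F)CC2)o1` gives 46.5%; compound 3 `CCCc1nc(-c2ccccc2)c(CNCCN2CCN(c3cccc(C(F)(F)F)c3)CC2)o1` gives 56.3%.

Compound 3 stands second highest of the three; compound 2 lies nearest to it, with a gap that is within the scatter, while compound 1 lies furthest, with a gap beyond it. Compound 4 `CCCc1nc(-c2ccccc2)c(CNCCN2CCN(c3cccc(Cl)c3)CC2)o1` differs from compound 3 by chloro in place of trifluoromethyl on an aromatic carbon.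

For the measured compounds named here, the steps that bear on this swap are a number 10.4 percentage points lower from compound 1 to compound 3 (beyond the scatter) and a number 9.8 percentage points higher from compound 2 to compound 3 (within the scatter): changing the aryl group on the amine nitrogen in the ring moves this assay only modestly, and one of these steps stays within the scatter. For compound 4 a step of a number 1.3 percentage points lower from compound 3 to compound 4 (within the scatter) is therefore expected, not beyond the scatter. Compound 4 is estimated at 55%, with a range from 40% to 70%.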

Compound 4, a percentage reported as inhibition, at one concentration (the size of the read-out at that concentration, not a potency): 51.2%
For compound 4 the middle estimate is 3.8 percentage points above the measured one, and the stated range covers the measured number.
By their numbers in this assay, from the lowest: compounds 2, 4 and 3 (each within the scatter of the next); then compound 1.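

Chloro in place of trifluoromethyl, one heavy atom for four, gives a number 5.1 percentage points lower from compound 3 to compound 4 (within the scatter) in this assay, so at this place the two groups cannot be told apart. The 3-chlorophenyl group also stays close to 2-fluorophenyl, with a number 4.7 percentage points higher from compound 2 to compound 4 (within the scatter), while 2,3-dimethylphenyl remains apart, with a number 15.5 percentage points lower from compound 1 to compound 4 (beyond the scatter). No supporting data bear on why these steps have the sizes they do. The compounds shown leave open whether a methoxy group, an amine or a carboxylic acid at this place would move the number beyond the scatter, and whether chloro would give a similar number elsewhere on the ring.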